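A few compounds are considered here, and "the series" means these few. Any claim that something is new, unique, unknown or untested is made for them only; others in the source may bear on it.

Working notes on the series built on the core of compound 1 `COc1ccc(CN(C(=O)Nc2ccc(F)c(Cl)c2)n2cnnc2)cc1OC`. In a functional assay on B16-F10 cells (Mus musculus) for cytotoxicity, read by MTT assay, with a stated time of 48 h (a higher number here means a weaker inhibitor, a lower number a stronger inhibitor), compound 1 gives 20700 nM. Compound 2 `COc1ccc(CN(C(=O)Nc2ccc(C#N)cc2)n2cnnc2)cc1OC` reaches only the limit of this assay, > 50000 nM. Compound 3 `COc1ccc(CN(C(=O)Nc2ccc(C)cc2)n2cnnc2)cc1OC` gives 29900 nM in this assay and holds the highest of the two numbers; the nearest step is a 1.4-fold higher number from compound 1 to compound 3 (0.16 log units; within the scatter). The steps of an at least 2.4-fold higher number from compound 1 to compound 2 (0.38 log units; beyond the scatter) and an at least 1.6-fold lower number from compound 2 to compound 3 (0.22 log units; that floor lies within the scatter) both vary the aryl on the amide-type nitrogen. Compound 4 `COc1cc(CN(C(=O)Nc2ccc(C)cc2)n2cnnc2)cc(OC)c1OC` differs from compound 3 by methoxy in place of hydrogen on an aromatic carbon. Within the data shown here, no measured step touches that ring, so the aryl steps give no direct guide; the working expectation in this assay is no step beyond the scatter. Compound 4 is estimated at 30000 nM (12000 nM to 75000 nM), an expected 1.0-fold higher number from compound 3 to compound 4 (0.00 log units; within the scatter).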

Compound 4, half-maximal inhibitory concentration: 46800 nM
Beside the measured number, compound 4's estimate is 1.6-fold (0.19 log units) below it, and the stated range covers the measured number.
By their numbers in this assay, from the lowest: compounds 1, 3 and 4 (each within the scatter of the next, the first and the last beyond it). At a limit, above all of these: compound 2.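

In this assay, among these compounds, the first step on the methoxy-bearing ring, methoxy in place of hydrogen, is a 1.6-fold higher number from compound 3 to compound 4 (0.19 log units; within the scatter), so with the 4-methylphenyl held fixed, this position takes a methoxy without a change that can be told from the scatter. Compound 2 stands at a limit of the assay, not at a number, and that limit bounds what can be read in this series: the limit of > 50000 nM in this assay, at which 1 of the 4 values shown sits.

As far as these compounds go, whether a hydroxy or an amine at this position would move the number stays open. So does whether the methoxy step reads the same with the 3-chloro-4-fluorophenyl of compound 1.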